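Carbonate-ester variant of a stable carbapenem-type scaffold

A few compounds are considered here, and "the series" means these few. Any claim that something is new, unique, unknown or untested is made for them only; others in the source may bear on it.

Measured compounds:
- compound 1 `CCOC(=O)C1=C(S[C@@H]2CN[C@H](C(=O)Nc3cccc(C(=O)O)c3)C2)[C@H](C)[C@@H]2[C@@H]([C@@H](C)O)C(=O)N12` — > 95%
- compound 2 `CCOC(=O)C1=C(S[C@@H]2CN[C@H](C(=O)Nc3cccc(C(=O)OCC)c3)C2)[C@H](C)[C@@H]2[C@@H]([C@@H](C)O)C(=O)N12` — > 95%
- compound 3 `CCCOC(=O)C1=C(S[C@@H]2CN[C@H](C(=O)Nc3cccc(C(=O)OCCC)c3)C2)[C@H](C)[C@@H]2[C@@H]([C@@H](C)O)C(=O)N12` — > 95%

In a physicochemical assay for metabolic stability, read by LC-MS, in phosphate buffer, with a stated time of 3 h, at pH 7.4, tested at 50 uM (on this read-out lower numbers stand for a less stable compound and higher numbers for a more stable compound), compound 1 gives > 95%, which is a limit of the assay and not a number. Compound 2 likewise sits at a limit in this assay, and so does compound 3. Compound 4 `COC(=O)OCOC(=O)C1=C(S[C@@H]2CN[C@H](C(=O)Nc3cccc(C(=O)O)c3)C2)[C@H](C)[C@@H]2[C@@H]([C@@H](C)O)C(=O)N12` has not yet been measured in this assay. It differs from compound 1 in one place: (methoxycarbonyl)oxy in place of methyl on a saturated chain carbon bound to an oxygen next to a carbonyl group.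

Within the data shown here, the only step between measured compounds that differs in one place, a step that the two limits leave unreadable from compound 1 to compound 2, is unreadable because both ends sit at a limit, as summarised by the limit of > 95% in this assay, at which 3 of the 3 values shown sit. Among the measured compounds shown here, the step from compound 1 to compound 4 changes a different position, so no measured step bears on it directly, and the remaining values show only that every measured compound stays at the limit.

With this in mind, compound 4 is expected to remain largely intact, at an estimated 88% (range 65% to 100%), meaning an expected step of a number at least 7 percentage points lower from compound 1 to compound 4 (that floor lies within the scatter) that may or may not exceed the usual scatter.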

Compound 4, percent of the compound remaining: > 95%
Compound 4: a limit, no number; the forecaster's own chance of this, stated with the estimate: 0.45%; middle value at least 7 percentage points away from the limit.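

The step from compound 1 to compound 4 cannot be read, since each of the two compounds sits at a limit of the assay and gives no number: the limit of > 95% in this assay, at which 4 of the 4 values shown sit. The compounds shown leave open whether (methoxycarbonyl)oxy in place of methyl changes the percent of compound remaining at all, or by how much.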